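Bromo for hydrogen on the shared core: expectation for compound 4

The compounds below may be only part of what the source reports. "The series", "measured", "known", "first", "only" and "open" are said of these compounds alone.

Measured compounds:
compound 1 `CC(c1ccc(-c2ccccc2)c(F)c1)c1nnc2n1N=C(c1ccccc1)CS2` — 9700 nM
compound 2 `CC(C)Cc1ccc(C(C)c2nnc3n2N=C(c2ccc(Br)cc2)CS3)cc1` — 7100 nM
compound 3 `COc1ccc2cc(C(C)c3nnc4n3N=C(c3ccc(Br)cc3)CS4)ccc2c1` — 11700 nM

In a functional assay on HCT-116 cells (Homo sapiens) for inhibition, read by sulforhodamine B assay, with a stated time of 72 h (a lower number here means a stronger inhibitor, a higher number a weaker inhibitor), compound 1 gives 9700 nM, the second highest of the three numbers. Its nearest neighbour is compound 3 and its furthest is compound 2, and both gaps lie within the usual scatter, so no order among the three can be read from these values.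

Compound 4 `CC(c1ccc(-c2ccccc2)c(F)c1)c1nnc2n1N=C(c1ccc(Br)cc1)CS2` differs from compound 1 by bromo in place of hydrogen on an aromatic carbon. Compound 2 and compound 3 already carry the 4-bromophenyl group and give numbers within the scatter of compound 1, so no step beyond the scatter is expected in this assay for this change.

For compound 4 the expected value is 9000 nM, with a range of 4500 nM to 18000 nM; this corresponds to an expected step of a 1.1-fold lower number from compound 1 to compound 4 (0.03 log units; within the scatter).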

Compound 4, half-maximal inhibitory concentration: 7100 nM
Compound 4: the middle estimate sits 1.3-fold (0.10 log units) above what was measured; the measured number falls inside the stated range.
By their numbers in this assay, from the lowest: compounds 2, 4, 1 and 3 (each within the scatter of the next).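

Phenyl to 4-bromophenyl gives the first step in the series between compounds differing in one place: in this assay the change shows a 1.4-fold lower number from compound 1 to compound 4 (0.14 log units; within the scatter) and no more. At this position, para to a large group, bromo in place of hydrogen therefore leaves the number within the scatter in the setting of compound 1. No measurement available here bears on the reason for this result.

On these data alone, whether an amine or a carboxylic acid at this position would give a step beyond the scatter remains open. Also open, as far as these compounds go, is whether the same change behaves alike with the other groups carried by compound 2 and compound 3.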